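Oxime ether triazole variants on a triterpenoid core

The source may report more compounds than this note shows. Statements on the series, on what has been measured and on what is new or still open speak of the compounds shown alone.

Measured so far:
- compound 1 `CC(C)=CCC/C(C)=C/CC/C(C)=C/CC[C@@H]1[C@@]2(C)CCC(=O)C(C)(C)[C@@H]2CC[C@@]1(C)O`, in a functional assay on DU-145 cells (Homo sapiens) for cytotoxicity, read by MTT assay, with a stated time of 48 h (a lower number here means a stronger inhibitor, a higher number a weaker inhibitor), compound 1 gives 13200 nM
- compound 2 `COc1cccc(-n2cc(CO/N=C3\CC[C@]4(C)[C@@H](CC/C=C(\C)CC/C=C(\C)CCC=C(C)C)[C@](C)(O)CC[C@H]4C3(C)C)nn2)c1`, in this assay compound 2 gives 30500 nM

Compound 2 holds the highest of the two numbers in this assay; its nearest neighbour is compound 1, whose lower number lies beyond the scatter, so compound 2 is the weaker inhibitor of the pair.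

Compound 3 `CC(C)=CCC/C(C)=C/CC/C(C)=C/CC[C@@H]1[C@@]2(C)CC/C(=N\OCc3cn(-c4ccc(Cl)cc4)nn3)C(C)(C)[C@@H]2CC[C@@]1(C)O` is not yet measured in this assay. It differs from compound 2 in one place: 4-chlorophenyl in place of 3-methoxyphenyl on an aromatic nitrogen. Among the compounds with values here, no measured pair in this set separates such a change on the aromatic nitrogen, so the data give no step to lean on. Compound 3 is expected to keep the oxime ether arrangement of compound 2 and to stay in the same weak range, with a step from compound 2 to compound 3 of a 1.2-fold lower number from compound 2 to compound 3 (0.09 log units; within the scatter) expected, that is none beyond the scatter. Compound 3 is estimated at 25000 nM, with a range from 10000 nM to 60000 nM.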

Compound 3, half-maximal inhibitory concentration: 16200 nM
Estimate against measurement, compound 3: 1.5-fold (0.19 log units) above, and the stated range covers the measured number.
By their numbers in this assay, from the lowest: compounds 1, 3 and 2 (each within the scatter of the next, the first and the last beyond it).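

In this assay, 4-chlorophenyl in place of 3-methoxyphenyl on the aromatic nitrogen of the five-membered aromatic ring with 3 nitrogen gives a 1.9-fold lower number from compound 2 to compound 3 (0.27 log units; within the scatter). This first reading at the position shows that exchanging these two aryl groups, with the loss of the one hydrogen-bond acceptor in the leaving group, does not separate compound 2 and compound 3 in this assay. No measurement at hand bears on the reason for this result.

From the compounds shown here alone, whether a carboxylic acid or an amine on a chain at that nitrogen would move the number beyond the scatter remains open. The step also changes the identity of the phenyl substituent and its place on the ring together, and these two changes remain unseparated.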